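Trading an Oxolane for a Methyl on a Shared Core

The compounds below may be only part of what the source reports. "The series", "measured", "known", "first", "only" and "open" are said of these compounds alone.

Three compounds have been measured in an ADME assay on microsomes from liver (Homo sapiens) for metabolic stability, read by LC-MS, using NADPH, with stated times of 10 min and 45 min, tested at 1 uM; a lower number here means slower removal, a higher number faster removal of the compound:
compound 1 `Cc1cc(C)c(CN2CCc3c(Cl)cc([C@@H](CO)[C@@H]4CCOC4)c(Cl)c3C2=O)c(=O)[nH]1` gives 25.3 uL/min;
compound 2 `COc1cc(C)[nH]c(=O)c1CN1CCc2c(Cl)cc([C@@H](O)C3COC3)c(Cl)c2C1=O` gives only a limit of the assay, < 7 uL/min;
compound 3 `COC(c1cc(Cl)c2c(c1Cl)C(=O)N(Cc1c(C)cc(C)[nH]c1=O)CC2)C1CCOC1` gives 136 uL/min; 93.3 uL/min; 128 uL/min; 108 uL/min (4 entries).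

Among these, compound 1 holds the only single number; compound 2 sits at a limit, and compound 3 is known through several repeats, (the several entries of compound 3 in this assay, 136 uL/min; 93.3 uL/min; 128 uL/min; 108 uL/min (4 entries)), which spread about as far as this kind of measurement usually scatters. Compound 4 `Cc1cc(C)c(CN2CCc3c(Cl)cc([C@H](C)CO)c(Cl)c3C2=O)c(=O)[nH]1` differs from compound 1 by methyl in place of oxolan-3-yl on a saturated chain carbon bound to an aromatic carbon and a saturated chain carbon. Among the measured compounds shown here, no measured pair of this kind is available, so the step in this assay is expected to be small, at most a little toward slower removal. The expected step is a 1.4-fold lower number from compound 1 to compound 4 (0.15 log units; within the scatter). Compound 4 is therefore estimated at 18 uL/min, within 7 uL/min to 45 uL/min.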

Compound 4, intrinsic clearance in a liver preparation (reported as CLH), per the amount of preparation that the assay uses: 15.8 uL/min
Compound 4: the middle estimate sits 1.1-fold (0.06 log units) above what was measured, and the stated range covers the measured number.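

In this assay, methyl in place of oxolan-3-yl on a saturated chain carbon bound to an aromatic carbon and a saturated chain carbon gives a 1.6-fold lower number from compound 1 to compound 4 (0.20 log units; within the scatter). Among the compounds shown here, this is the first step read at this place, and it shows that the ring can be exchanged for methyl here with no change beyond what repeats of a single compound show: the several entries of compound 3 in this assay, 136 uL/min; 93.3 uL/min; 128 uL/min; 108 uL/min (4 entries). On these data alone, whether an amine, a carboxylic acid or a longer chain at this place would give a similar number remains open. So does whether the same exchange would behave alike elsewhere on the shared core.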